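Butyl in place of hydrogen on the carbamate aryl ring

The source may hold more compounds than are shown below. What is called first, only, known or untested is meant among the compounds shown, and "the series" means these compounds.

Within the data shown here, compound 3 `C=C1C(=O)OC[C@H]1CCOC(=O)Nc1ccccc1` carries an unsubstituted phenyl carbamate on the shared core and, in a functional assay on RAW264.7 cells (Mus musculus) for inhibition, with a stated time of 30 min (a lower number here means a stronger inhibitor, a higher number a weaker inhibitor), compound 3 gives 390 nM, the lowest of the three numbers so far. Its nearest neighbour is compound 1 `C=C1C(=O)OC[C@H]1CCOC(=O)Nc1ccc(I)cc1`, which in this assay gives 490 nM; the step of a 1.3-fold lower number from compound 1 to compound 3 (0.10 log units; within the scatter) is within the scatter, so hydrogen and iodo at this position read alike. Compound 2 `C=C1C(=O)OC[C@@H]1CCOC(=O)Nc1ccc(CCCC)cc1` has butyl in place of hydrogen on the other enantiomer of the core. In this assay compound 2 gives 1230 nM, a higher number than compound 3 and beyond the scatter of it.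

Compound 4 `C=C1C(=O)OC[C@H]1CCOC(=O)Nc1ccc(CCCC)cc1` is the enantiomer of compound 2 and differs from compound 3 by butyl in place of hydrogen on an aromatic carbon, the place being para to a large group. Among the measured compounds shown here, no measured step covers this butyl change on this enantiomer. What compound 2 shows is a higher number with butyl on the other core; the iodo step is within the scatter. A higher number is therefore expected for compound 4, and the step of a 2.6-fold higher number from compound 3 to compound 4 (0.41 log units; beyond the scatter) is the estimate. In this assay compound 4 is estimated at 1000 nM, within a range from 400 nM to 2500 nM.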

Compound 4, half-maximal inhibitory concentration: 620 nM
For compound 4 the middle estimate is 1.6-fold (0.21 log units) above the measured one; measured number inside the range.
By their numbers in this assay, from the lowest: compounds 3, 1, 4 and 2 (each within the scatter of the next, the first and the last beyond it).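

On this enantiomer of the core, the step of a 1.6-fold higher number from compound 3 to compound 4 (0.20 log units; within the scatter) shows that butyl para to a large group reads alike with hydrogen in this assay and the step of a 1.3-fold higher number from compound 1 to compound 4 (0.10 log units; within the scatter) puts butyl level with iodo as well. Across compounds 1, 3 and 4, the group at this place therefore makes no readable difference, a statement limited to hydrogen, iodo and butyl. The step of a 2.0-fold lower number from compound 2 to compound 4 (0.30 log units; within the scatter) also stays within the scatter, so with butyl on the ring the two configurations of the core do not separate, and this comparison isolates configuration because nothing else changes: the fact that compounds 2 and 4 differ only in the configuration as drawn.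

From the compounds shown here alone, whether a carboxylic acid, an amine or a chain longer than butyl at this place would separate from hydrogen stays open. Also open, going by these compounds, is whether the two configurations of the core read alike with hydrogen or iodo on the ring.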